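Benzylamino replaces 4-chlorophenyl on a carbonyl carbon

A few compounds are considered here, and "the series" means these few. Any claim that something is new, unique, unknown or untested is made for them only; others in the source may bear on it.

In an ADME assay on Karpas-1106P cells (Homo sapiens) for cytotoxicity (a higher number here means that more compound is needed for the effect, a lower number that less compound is needed), compound 1 `Cc1ccc(S(=O)(=O)N[C@@H](CC(=O)NC(C)(C)C)C(=O)NCCNC(=O)c2cc(Cl)ccn2)cc1` gives > 11100 nM as a limit of the assay. Compound 2 `Cc1ccc(S(=O)(=O)N[C@@H](CC(=O)NC(C)(C)C)C(=O)NCCNC(=O)c2ccc(Cl)cc2)cc1` gives > 11100 nM as a limit too, and it shares the limit of > 11100 nM in this assay, at which 2 of the 2 values shown sit, with no number of its own. Compound 3 `Cc1ccc(S(=O)(=O)N[C@@H](CC(=O)NC(C)(C)C)C(=O)NCCNC(=O)NCc2ccccc2)cc1` carries benzylamino in place of 4-chlorophenyl on a carbonyl carbon. Going by the values given here, the only measured step is a step that the two limits leave unreadable from compound 1 to compound 2 and gives no size to carry forward, so no step beyond the scatter is expected in this assay for this change. The estimated change is a step that the limit leaves unreadable from compound 2 to compound 3 with no direction favoured. Compound 3 is expected near 12000 nM with an estimated range (5000 nM to 30000 nM) and may well read as a limit again.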

Compound 3, half-maximal effective concentration: > 11100 nM
Compound 3: a limit, no number; the forecaster's own chance of this, stated with the estimate: 80%; the middle value lies beyond the limit too.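

Compound 3 gives > 11100 nM as a limit of the assay, and the steps to it from compound 1 and compound 2 cannot be read: the limit of > 11100 nM in this assay, at which 3 of the 3 values shown sit.

The compounds shown leave open whether exchanging 4-chloropyridin-2-yl, 4-chlorophenyl or benzylamino changes the read-out at all.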